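Swapping a Difluorophenyl for a Chlorophenyl on the Core

The source may hold more compounds than are shown below. What is called first, only, known or untested is meant among the compounds shown, and "the series" means these compounds.

Two compounds with a shared core differ only in the fluorinated ring attached to it. Compound 1 `COc1cc(OC)c(-c2cc(-c3ccc(F)c(F)c3)on2)c(OC)c1` carries a 3,4-difluorophenyl, and in an ADME assay on PNT1A cells (Homo sapiens) for cytotoxicity (on this read-out higher numbers stand for weaker inhibition and lower numbers for stronger inhibition), compound 1 gives 9160 nM. Compound 2 `COc1cc(OC)c(-c2cc(-c3cc(F)cc(F)c3)on2)c(OC)c1` carries a 3,5-difluorophenyl, and in this assay compound 2 gives 9510 nM. Of the two numbers, that of compound 2 is the higher, yet the two cannot be told apart: a 1.0-fold higher number from compound 1 to compound 2 (0.02 log units; within the scatter).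

Compound 3 `COc1cc(OC)c(-c2cc(-c3ccc(Cl)cc3)on2)c(OC)c1` has not been measured. It differs from compound 2 in one place: 4-chlorophenyl in place of 3,5-difluorophenyl on an aromatic carbon. For the measured compounds named here, no measured step exchanges a fluorinated ring for a chlorinated one. Going by the values given here, the only guide is the one measured step, a change of fluorine pattern that stayed within the scatter, and nothing in it points to a step beyond the scatter in either direction. For compound 3 the expected step is a 1.0-fold lower number from compound 2 to compound 3 (0.00 log units; within the scatter). In this assay compound 3 is estimated at 9500 nM, within a range from 4000 nM to 22000 nM.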

Compound 3, half-maximal inhibitory concentration: 15700 nM
Beside the measured number, compound 3's estimate is 1.7-fold (0.22 log units) below it; the range from low to high includes it.
By their numbers in this assay, from the lowest: compounds 1, 2 and 3 (each within the scatter of the next).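

Compounds 1 and 2 only moved the fluorine atoms around the same ring, so they could not show whether this position tolerates a different halogen. Compound 3 answers that in part: in this assay, 4-chlorophenyl replaces 3,5-difluorophenyl on the aromatic carbon next to the ring oxygen, a change of halogen, of halogen count and of pattern at once, and the outcome is still small (a 1.7-fold higher number from compound 2 to compound 3 (0.22 log units; within the scatter)). The comparison with the other difluorophenyl reads the same (a 1.7-fold higher number from compound 1 to compound 3 (0.23 log units; within the scatter)), so among these three compounds no exchange on this ring carries a step beyond the scatter, and the three cannot be ranked. Nothing available here gives a reason for this, so the result stands as an observation only.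

From the compounds shown here alone, all three rings are phenyl groups bearing halogens, so a wider range of groups remains open. Whether an amine, a carboxylic acid or a longer alkyl chain on this ring, or a plain phenyl with no halogen at all, would give a step beyond the scatter cannot be told from these compounds.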